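The source may report more compounds than this note shows. Statements on the series, on what has been measured and on what is new or still open speak of the compounds shown alone.

Measured compounds and their values:
Compound 1, `COc1cc(N(C)CCN(C)C)c(NC(=O)/C=C\C(C)C)cc1Nc1nccc(-c2cn(C)c3ccccc23)n1`: 612 nM
Compound 2, `COc1cc(N(C)CCN(C)C)c(NC(=O)/C=C\C(C)C)cc1Nc1nccc(-c2cn(C)c3ccc(F)cc23)n1`: 6140 nM
Compound 3, `COc1cc(N(C)CCN(C)C)c(NC(=O)/C=C\C(C)C)cc1Nc1ncc(C#N)c(-c2cn(C)c3ccc(F)cc23)n1`: 185 nM

These three share one core and differ at single positions. In a functional assay on A549 cells (Homo sapiens) for antiproliferative activity, read by MTT assay, with a stated time of 72 h (on this read-out higher numbers stand for weaker inhibition and lower numbers for stronger inhibition), compound 2 gives the highest number of the three, that is the weakest inhibition. Compound 1 sits a 10-fold higher number from compound 1 to compound 2 (1.00 log units; beyond the scatter) away, and compound 3 lies a 33-fold lower number from compound 2 to compound 3 (1.52 log units; beyond the scatter) further on the other side.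

Compound 4, `COc1cc(N(C)CCN(C)C)c(NC(=O)/C=C\C(C)C)cc1Nc1nc(C)cc(-c2cn(C)c3ccc(F)cc23)n1`, is not yet measured. It differs from compound 2 by methyl in place of hydrogen on an aromatic carbon. Among the measured compounds shown here, no measured step adds a methyl, so the expectation rests on the two steps that touch compound 2. The step of a 33-fold lower number from compound 2 to compound 3 (1.52 log units; beyond the scatter) shows that a small group on the same six-membered ring can move this assay by a large amount; the step of a 10-fold higher number from compound 1 to compound 2 (1.00 log units; beyond the scatter) shows a change on the indole ring acting the opposite way. For a methyl a smaller step is expected than for the cyano, so the number for compound 4 is estimated at 2500 nM, within 500 nM to 12000 nM, which would mean an expected step of a 2.5-fold lower number from compound 2 to compound 4 (0.39 log units; beyond the scatter).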

Compound 4, half-maximal inhibitory concentration: 9080 nM
Compound 4: middle estimate off by 3.6-fold (0.56 log units), on the low side; low and high end bracket the measured number.
By their numbers in this assay, from the lowest: compound 3; then compound 1; then compounds 2 and 4 (each within the scatter of the next).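

In this assay, methyl in place of hydrogen on the aromatic carbon next to the ring nitrogen gives a 1.5-fold higher number from compound 2 to compound 4 (0.17 log units; within the scatter), so at this position, adding this one carbon produces no change that can be told from the usual scatter. The earlier 33-fold lower number from compound 2 to compound 3 (1.52 log units; beyond the scatter), with cyano in place of hydrogen, therefore does not mean that every small group on this six-membered ring moves the number by a large amount, although the two steps differ in both the group and the ring carbon that carries it. No measurement here explains why the methyl step stays within the scatter.

From the compounds shown here alone, it remains open whether a longer chain such as propyl, or an amine, would be tolerated at this carbon in the same way. The compounds shown also leave open whether methyl here would behave alike alongside the cyano of compound 3.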